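The source may report more compounds than this note shows. Statements on the series, on what has been measured and on what is new or still open speak of the compounds shown alone.

Working notes on the thiol-glycine series in an assay on isolated protein for inhibition of Neprilysin (Oryctolagus cuniculus); a higher number here means a weaker inhibitor, a lower number a stronger inhibitor.

Compound 1 `O=C(NCC(=O)N1[C@@H](c2ccccc2)CC[C@H]1C(=O)O)[C@@H](S)Cc1ccc(O)cc1` gives 3.4 nM in this assay. Compound 2 `Nc1ccc(C[C@H](S)C(=O)NCC(=O)N2[C@@H](c3ccccc3)CC[C@H]2C(=O)O)cc1` gives 1.8 nM; it differs from compound 1 by amino in place of hydroxy on an aromatic carbon, and the step is a 1.9-fold lower number from compound 1 to compound 2 (0.28 log units; within the scatter). Compound 3 `O=C(NCC(=O)N1[C@@H](c2ccc(O)cc2)CC[C@H]1C(=O)O)[C@@H](S)Cc1ccc(O)cc1` gives 6.36 nM; it differs from compound 1 by hydroxy in place of hydrogen on an aromatic carbon, and the step is a 1.9-fold higher number from compound 1 to compound 3 (0.27 log units; within the scatter). Of the three measured values, compound 3 carries the highest number, and the gap to compound 2 is beyond the scatter, while the gap to compound 1 is not.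

Compound 4 `Nc1ccc([C@H]2CC[C@@H](C(=O)O)N2C(=O)CNC(=O)[C@@H](S)Cc2ccc(O)cc2)cc1` has not yet been measured in this assay. It differs from compound 3 by amino in place of hydroxy on an aromatic carbon. This is the same change already seen between compound 1 and compound 2, with the two place descriptions agreeing word for word; the cores of compound 3 and compound 4 differ from those of compound 1 and compound 2 by hydroxy in place of hydrogen on an aromatic carbon. Going by the values given here, the only precedent for the change is the single step between compound 1 and compound 2, which fell within the scatter, so a step of similar size is expected here, taken from the value of compound 3 6.36 nM. Compound 4 is therefore expected to come in near 3.5 nM. For compound 4 the estimated range is expected to run from 1.5 nM to 8 nM. The expected step is a 1.8-fold lower number from compound 3 to compound 4 (0.26 log units; within the scatter); a single precedent is a thin basis, and a result anywhere within the scatter of compound 3 would not contradict it.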

Compound 4, half-maximal inhibitory concentration: 26 nM
Beside the measured number, compound 4's estimate is 7.4-fold (0.87 log units) below it; measured number above the stated range.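

In this assay the exchange of 4-hydroxyphenyl for 4-aminophenyl gives a 4.1-fold higher number from compound 3 to compound 4 (0.61 log units; beyond the scatter) and so does not repeat the earlier step; the same compound also stands apart from the core without a substituent on that ring, with a 7.6-fold higher number from compound 1 to compound 4 (0.88 log units; beyond the scatter) as the reading. Amino in place of hydroxy therefore does not carry from one core to the other as a fixed increment in this series: the same change on two cores in this assay, a 1.9-fold lower number (0.28 log units; within the scatter) from compound 1 to compound 2 and a 4.1-fold higher number (0.61 log units; beyond the scatter) from compound 3 to compound 4, 7.7-fold (0.89 log units) apart, beyond the scatter of two such steps. Going by these compounds alone, this does not show why the two steps differ or that the core alone decides the outcome, since there are only two steps and the exchanged hydroxy stands on a different aromatic ring of the molecule in each, so a change of core and a change of ring cannot be told apart.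

The compounds shown leave open how amino in place of hydroxy reads on one and the same aromatic ring across two cores, and what amino groups on both aromatic rings at once would give. Also open, on these data alone, is whether a methoxy group or a fluorine atom in the place of the amino group on the ring of compound 4 would follow compound 3 or compound 4.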